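The source may report more compounds than this note shows. Statements on the series, on what has been measured and on what is new or still open speak of the compounds shown alone.

Compound 2 `COc1ccc(F)cc1CNCCCNc1ccnc2cc(CC(C)C)ccc12` and compound 1 `CC(C)Cc1ccc2c(NCCCNCc3ccco3)ccnc2c1` share one core and differ only at a chain end. In a physicochemical assay for solubility, with a stated time of 18 h, at pH 7.4 (on this read-out lower numbers stand for lower solubility and higher numbers for higher solubility), compound 1 gives 4200 nM, and compound 2 gives 4200 nM, level with it. Going by the values given here, the single measured step, no change at the digits printed from compound 1 to compound 2 (within the scatter), swaps a group on a chain carbon and leaves the read-out where it was. Compound 3 `COc1ccc(F)cc1CNCCCNc1ccnc2cc(-c3cccc4ccccc34)ccc12` brings a different kind of change: naphthalen-1-yl in place of isobutyl on an aromatic carbon. Among the compounds with values here, no measured step touches this position or adds two aromatic rings, which leaves no direct precedent. For compound 3 the expected step is an 8.4-fold lower number from compound 2 to compound 3 (0.92 log units; beyond the scatter), a fall beyond the scatter. Compound 3 is estimated at 500 nM, with a range from 100 nM to 2500 nM.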

Compound 3, solubility: 32000 nM
Beside the measured number, compound 3's estimate is 64-fold (1.81 log units) below it; the whole stated range lies below it.
By their numbers in this assay, from the lowest: compounds 1 and 2 (each within the scatter of the next); then compound 3.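

Putting naphthalen-1-yl in place of isobutyl on this aromatic carbon gives a 7.6-fold higher number from compound 2 to compound 3 (0.88 log units; beyond the scatter). So in this assay this position can move the read-out, unlike the chain end changed between compound 1 and compound 2. Nothing available explains this rise.

Going by these compounds alone, with only two groups compared at this carbon, it remains open how a smaller ring such as phenyl, an amine or a carboxylic acid would behave there. Going by these compounds, it is also open whether the same swap would give a similar step with the furan-2-yl chain end of compound 1.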